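Pyridin-2-yl in place of furan-3-yl: a step without precedent

This account rests on a few compounds, and the source may have more. Where it says the series, first, only, none or still open, it means among the compounds named here.

Measured so far in a functional assay on T47D cells (Homo sapiens) for cytotoxicity, read by CCK-8 assay; a higher number here means a weaker inhibitor, a lower number a stronger inhibitor:
compound 1 `Oc1ccc(-c2cc(-c3ccoc3)cc(-c3cccc(O)c3)n2)cc1`, 2610 nM
compound 2 `Oc1ccc(-c2cc(-c3ccoc3)cc(-c3ccc(O)cc3)n2)cc1`, 3460 nM

Among the measured compounds shown here, compound 1 holds the lowest of the two numbers, yet its only neighbour is compound 2, and the step of a 1.3-fold higher number from compound 1 to compound 2 (0.12 log units; within the scatter) lies within the scatter. Compound 3 `Oc1ccc(-c2cc(-c3ccccn3)cc(-c3cccc(O)c3)n2)cc1` differs from compound 1 by pyridin-2-yl in place of furan-3-yl on an aromatic carbon. For the measured compounds named here, no measured step exchanges one of these ring groups; the single known step concerns the hydroxyphenyl groups and was small. Nothing here argues for a move beyond the scatter, so compound 3 is expected to land near compound 1. The estimate therefore implies a 1.1-fold higher number from compound 1 to compound 3 (0.03 log units; within the scatter). For compound 3 the expected value is 2800 nM, between 1000 nM and 8000 nM.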

Compound 3, half-maximal inhibitory concentration: 980 nM
For compound 3 the middle estimate is 2.9-fold (0.46 log units) above the measured one, outside the stated range (below it).
By their numbers in this assay, from the lowest: compound 3; then compounds 1 and 2 (each within the scatter of the next).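

In this assay, among the compounds shown here, the ring group opposite the ring nitrogen proves able to shift the number: pyridin-2-yl in place of furan-3-yl gives a 2.7-fold lower number from compound 1 to compound 3 (0.43 log units; beyond the scatter) and is the only step here beyond the scatter. The earlier exchange of hydroxyphenyl groups stayed within it, so this position responds where that change did not. No measurement at hand explains this difference.

The compounds shown do not separate the effect of the ring nitrogen from that of the six-membered ring, which a plain phenyl group at this position could address. From the compounds shown here alone, how an aminomethyl group or a carboxylic acid would fare there also remains open.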